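Benzyl in place of a dimethoxymethyl on a thioether

This account rests on a few compounds, and the source may have more. Where it says the series, first, only, none or still open, it means among the compounds named here.

Measured so far:
compound 1 `c1ccc(-c2nc(SCC3OCCCO3)[nH]c2-c2ccccc2)cc1` gives 180 nM in an assay on microsomes from liver for inhibition of sterol O-acyltransferase 1 (Rattus norvegicus); a lower number here means a stronger inhibitor, a higher number a weaker inhibitor
compound 2 `COC(CSc1nc(-c2ccccc2)c(-c2ccccc2)[nH]1)OC` gives 580 nM in this assay

Compound 2 stands as the higher of the two numbers, the step of a 3.2-fold higher number from compound 1 to compound 2 (0.51 log units; beyond the scatter) lying beyond the scatter. Compound 3 `c1ccc(CSc2nc(-c3ccccc3)c(-c3ccccc3)[nH]2)cc1` carries the change (phenyl in place of dimethoxymethyl on a saturated chain carbon bound to a sulfur). For the measured compounds named here, no measured step bears directly on it; the one measured step shows only that this position tolerates a modest change. The step of a 1.9-fold lower number from compound 2 to compound 3 (0.29 log units; within the scatter) is therefore expected to be small. Compound 3 is estimated at 300 nM, within 80 nM to 1200 nM.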

Compound 3, half-maximal inhibitory concentration: 290 nM
The estimate for compound 3 lay 1.0-fold (0.01 log units) above the measured number, within the range that was stated.
By their numbers in this assay, from the lowest: compounds 1, 3 and 2 (each within the scatter of the next, the first and the last beyond it).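

Phenyl has no hydrogen-bond acceptors, yet putting it in place of dimethoxymethyl gives a 2.0-fold lower number from compound 2 to compound 3 (0.30 log units; within the scatter), so the oxygens of the leaving group are not needed to hold this level of inhibition. Against the oxygen-containing ring of compound 1, the all-carbon ring gives a 1.6-fold higher number from compound 1 to compound 3 (0.21 log units; within the scatter), so compound 3 cannot be told apart from either of the earlier compounds. No supporting measurement is available to explain this.

Going by these compounds, whether an amine, a carboxylic acid or a longer chain on this saturated chain carbon bound to a sulfur would keep the number in this assay stays open. So does the effect of a chlorine or a methoxy group on the phenyl.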